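A few compounds are considered here, and "the series" means these few. Any claim that something is new, unique, unknown or untested is made for them only; others in the source may bear on it.

In a toxicity assay on GES1 cells (Homo sapiens) for inhibition, read by MTT assay, with a stated time of 72 h (a lower number here means a stronger inhibitor, a higher number a weaker inhibitor), compound 1, `Cc1cc(N2CC[C@@H](C)[C@@H](N(C)c3ncnc4[nH]ccc34)C2)n2ncnc2n1`, gives 57900 nM. Compound 2, `Cc1cc(N2CC[C@@H](C)[C@@H](N(C)c3ncnc4[nH]ccc34)C2)n2nc(SCc3ccccc3Br)nc2n1`, gives > 100000 nM, which is a limit of the assay and not a number. Within the data shown here, compound 3, `Cc1cc(N2CC[C@@H](C)[C@@H](N(C)c3ncnc4[nH]ccc34)C2)n2nc(SCc3cc(Cl)ccc3Cl)nc2n1`, gives 87500 nM, which lies within the scatter of compound 1, the only other compound with an actual number. So compound 3 stands in a very weakly inhibiting group, and one thing to keep in mind is the limit of > 100000 nM in this assay, at which 1 of the 3 values shown sits.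

Compound 4, `Cc1cc(N2CC[C@@H](C)[C@@H](N(C)c3ncnc4[nH]ccc34)C2)n2nc(SCc3ccc([N+](=O)[O-])cc3)nc2n1`, has not yet been measured. It differs from compound 3 as follows: 4-nitrophenyl in place of 2,5-dichlorophenyl on a saturated chain carbon bound to a sulfur. In words, 4-nitrophenyl takes the place of 2,5-dichlorophenyl on a saturated chain carbon bound to a sulfur.

Among the measured compounds shown here, three measured steps bear on this change. Adding the (2,5-dichlorobenzyl)sulfanyl group gave a 1.5-fold higher number from compound 1 to compound 3 (0.18 log units; within the scatter). Adding the (2-bromobenzyl)sulfanyl group gave an at least 1.7-fold higher number from compound 1 to compound 2 (0.23 log units; that floor lies within the scatter). The closest parallel is a swap of one aryl group for another on the same chain, which gave an at least 1.1-fold lower number from compound 2 to compound 3 (0.05 log units; that floor lies within the scatter). None of these three is shown to go beyond the scatter, although two of them are only floors, so no large shift is expected here.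

The expected change is an estimated 1.3-fold lower number from compound 3 to compound 4 (0.10 log units; within the scatter), and it is not expected to exceed the scatter. For compound 4 the estimated value is 70000 nM, with an expected range from 30000 nM to 130000 nM.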

Compound 4, half-maximal inhibitory concentration: 36600 nM
Beside the measured number, compound 4's estimate is 1.9-fold (0.28 log units) above it, and the stated range covers the measured number.
By their numbers in this assay, from the lowest: compounds 4, 1 and 3 (each within the scatter of the next, the first and the last beyond it). At a limit, above all of these: compound 2.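

In this assay, the swap of one aryl group for another on a saturated chain carbon bound to a sulfur now gives a step beyond the scatter, with 4-nitrophenyl in place of 2,5-dichlorophenyl (a 2.4-fold lower number from compound 3 to compound 4 (0.38 log units; beyond the scatter)). The swap of 2-bromophenyl for 4-nitrophenyl at this place also passes the scatter (an at least 2.7-fold lower number from compound 2 to compound 4 (0.43 log units; beyond the scatter)), but that step is only a floor, as compound 2 stands at a limit of the assay and not at a number: (the limit of > 100000 nM in this assay, at which 1 of the 4 values shown sits). Adding the whole (4-nitrobenzyl)sulfanyl group in place of hydrogen on an aromatic carbon stays within the scatter (a 1.6-fold lower number from compound 1 to compound 4 (0.20 log units; within the scatter)), so among these compounds the choice of aryl group matters more than the presence of the group as a whole.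

The compounds shown cannot separate the entry of the nitro group from the loss of the two chlorine atoms, as both happen in the same step. An unsubstituted phenyl, a 4-chlorophenyl or a 4-aminophenyl on the same chain would pull these apart, and a carboxylic acid there would test a quite different kind of group.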